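Cyano to Carbamoyl on Two Related Cores: Acid Dissociation

The source may report more compounds than this note shows. Statements on the series, on what has been measured and on what is new or still open speak of the compounds shown alone.

Three compounds have so far been characterised in a physicochemical assay for acid dissociation, using potentiometric titration. Compound 1 `CCCN1CCN(c2cccc(C#N)c2)CC1` gives 7.67 in this assay. Compound 3 `CCCN1CCN(c2cccc(C(N)=O)c2)CC1` differs from it by carbamoyl in place of cyano on an aromatic carbon and gives 7.76 in this assay; the step between the two is a number 0.09 log units higher from compound 1 to compound 3 (within the scatter). Compound 2 `CCCN1CCN(c2ccc(C#N)cc2)CC1` gives 7.78 in this assay. The difference between the core of compound 2 and the core of compound 1 is not broken down here, and the values of compound 2, compound 3 and compound 1 all lie within the scatter of one another, so no order among them can be read from these numbers.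

Compound 4 `CCCN1CCN(c2ccc(C(N)=O)cc2)CC1` has not yet been measured in this assay. Relative to compound 2 it carries carbamoyl in place of cyano on an aromatic carbon. Among the measured compounds shown here, this is the same kind of change as the one leading from compound 1 to compound 3, but the surroundings differ: in compound 3 the carbamoyl stands meta to a group of 9 heavy atoms, whereas in compound 4 it stands para to a group of 9 heavy atoms. Because a number 0.09 log units higher from compound 1 to compound 3 (within the scatter) stayed within the scatter, the step from compound 2 to compound 4 is expected to be a number 0.07 log units higher from compound 2 to compound 4 (within the scatter), a change of about the same small size. The value of compound 4 in this assay is accordingly estimated at 7.85, with a likely range from 7.55 to 8.15.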

Compound 4, acid dissociation constant: 7.84
Estimate against measurement, compound 4: 0.01 log units above; measured number inside the range.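

In this assay carbamoyl in place of cyano on an aromatic carbon gives a number 0.06 log units higher from compound 2 to compound 4 (within the scatter) and on the other core gives a number 0.09 log units higher from compound 1 to compound 3 (within the scatter) so on both cores the step stays inside the usual scatter of repeated measurements. For these two related cores the change therefore carries over in one limited sense: neither core shows a step that can be told apart from the scatter, and this holds for compound 4, where the carbamoyl stands para to a group of 9 heavy atoms, as it does for compound 3 on the core of compound 1. It does not show that the two steps truly differ in size or that they are truly the same, nor that the change moves this number at all, and two pairs give no rule beyond these four compounds; no evidence on the reason for this outcome is at hand.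

The compounds shown leave open whether a carboxylic acid or an amine on the same aromatic carbon would also stay within the scatter of the nitrile. They also leave open whether the small steps seen here would persist with a longer chain in place of the propyl group on the shared core.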